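Replacing Methoxy by Bromo in Compound 4

This account rests on a few compounds, and the source may have more. Where it says the series, first, only, none or still open, it means among the compounds named here.

The series shares one core, seen in compound 1 `CC(C)c1ccc(NC(=O)c2csc(Cc3c(Cl)cccc3Cl)n2)cc1`, compound 2 `CC(C)(C)c1ccc(NC(=O)c2csc(Cc3c(Cl)cccc3Cl)n2)cc1` and compound 3 `COc1ccc(NC(=O)c2csc(Cc3c(Cl)cccc3Cl)n2)cc1`. In an assay on CHO cells, read by calcium flux (a lower number here means a stronger inhibitor, a higher number a weaker inhibitor), compound 1 gives 520 nM and compound 2 gives 300 nM, with a 1.7-fold lower number from compound 1 to compound 2 (0.24 log units; within the scatter). Compound 3 reaches only > 4000 nM, which is a limit of the assay and not a number. Compound 3 therefore stands at the weak end of the numbers shown. The measured steps of an at least 7.6-fold higher number from compound 1 to compound 3 (0.88 log units; beyond the scatter) and an at least 13-fold higher number from compound 2 to compound 3 (1.12 log units; beyond the scatter) both show methoxy giving the highest number. Compound 4 `O=C(Nc1ccc(Br)cc1)c1csc(Cc2c(Cl)cccc2Cl)n1` differs from compound 3 by bromo in place of methoxy on an aromatic carbon. Going by the values given here, no measured step involves bromo, so the direction rests on little. Because compound 3 sits at the limit (the limit of > 4000 nM in this assay, at which 1 of the 3 values shown sits), compound 4 is expected to move toward a lower number, by an at least 2.6-fold lower number from compound 3 to compound 4 (0.42 log units; beyond the scatter). Compound 4 is estimated at 1500 nM, within 300 nM to 6000 nM.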

Compound 4, half-maximal inhibitory concentration: 460 nM
Beside the measured number, compound 4's estimate is 3.3-fold (0.51 log units) above it, within the range that was stated.
By their numbers in this assay, from the lowest: compounds 2, 4 and 1 (each within the scatter of the next). At a limit, above all of these: compound 3.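

In this assay, the change from methoxy to bromo gives an at least 8.6-fold lower number from compound 3 to compound 4 (0.93 log units; beyond the scatter), so this position, para to a large group, does not need an alkyl group. Bromo stays level with both alkyl groups, with a 1.5-fold higher number from compound 2 to compound 4 (0.19 log units; within the scatter) and a 1.1-fold lower number from compound 1 to compound 4 (0.05 log units; within the scatter), and so a single heavy atom serves here as well as isopropyl or tert-butyl. Compound 3 remains alone at a limit: the limit of > 4000 nM in this assay, at which 1 of the 4 values shown sits.

The compounds shown do not tell whether the oxygen of methoxy accounts for its separation from the other groups. Nor do they tell how ethyl, chloro, an amine or a carboxylic acid would read at this position.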